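The source may report more compounds than this note shows. Statements on the series, on what has been measured and on what is new or still open speak of the compounds shown alone.

Working notes on the aziridine-nitrile urea series.

Of the compounds shown here, three have been measured in a functional assay on RPMI-8226 cells (Homo sapiens) for inhibition; a higher number here means a weaker inhibitor, a lower number a stronger inhibitor. Compound 1 `CCOC(=O)CNC(=O)N1CC1C#N` gives 25000 nM. Compound 2 `CCCCNC(=O)N1CC1C#N` gives 17000 nM. Compound 3 `CCOC(=O)c1ccc(NC(=O)N2CC2C#N)cc1` gives 3000 nM. Compound 3 therefore stands at the lowest number of the three, beyond the scatter from both compound 2 and compound 1; the two alkyl ureas, compound 1 and compound 2, sit close to one another and well above it.

The next compound, compound 4 `N#CC1CN1C(=O)Nc1ccccc1`, keeps the shared core and the aromatic urea of compound 3 but drops the ester: hydrogen in place of ethoxycarbonyl on an aromatic carbon. For the measured compounds named here, no measured pair in the set isolates this change, so the step can only be anticipated from the spread between compound 3 and the alkyl ureas, which shows that the aromatic substituent carries most of the gain. Removing the ethoxycarbonyl is expected to cost some potency in this assay, giving a step of a 2.0-fold higher number from compound 3 to compound 4 (0.30 log units; within the scatter) towards a higher number, though less than the gap back to compound 2. Compound 4 is estimated at 6000 nM, with a range from 2000 nM to 20000 nM.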

Compound 4, half-maximal inhibitory concentration: 5300 nM
For compound 4 the middle estimate is 1.1-fold (0.05 log units) above the measured one; measured number inside the range.
By their numbers in this assay, from the lowest: compounds 3 and 4 (each within the scatter of the next); then compounds 2 and 1 (each within the scatter of the next).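

In this assay, for the compounds shown here, hydrogen in place of ethoxycarbonyl on an aromatic carbon, para to a group of 8 heavy atoms, gives a 1.8-fold higher number from compound 3 to compound 4 (0.25 log units; within the scatter), so this is the first single-place comparison, and the two compounds cannot be told apart. The ethoxycarbonyl is therefore not needed at this position to hold the number in this range: compound 4, with the aromatic ring bearing no substituent, reads 5300 nM, against 17000 nM for compound 2. No measurement available here accounts for this tolerance.

The compounds shown leave open whether a carboxylic acid, an amine or a longer ester on the same aromatic carbon would move the number beyond the scatter. Also open, as far as these compounds go, is what a fluorine or methoxy group would do on the other carbons of the ring.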